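A few compounds are considered here, and "the series" means these few. Any claim that something is new, unique, unknown or untested is made for them only; others in the source may bear on it.

Compound 1 `O=C(Nc1ccc(Br)cc1)N[C@H]1CC[C@H](Oc2ccc(F)cc2)CC1` gives > 20000 nM in a functional assay on CRL2813 cells (Homo sapiens) for cytotoxicity, read by sulforhodamine B assay, with a stated time of 5 days; on this read-out lower numbers stand for stronger inhibition and higher numbers for weaker inhibition; that value is a limit of this assay, not a number.
Compound 3 `COc1ccc(NC(=O)N[C@H]2CC[C@H](Oc3ccc(F)cc3)CC2)cc1` gives > 20000 nM; this too is a limit of this assay.
Among the compounds with values here, compound 2 `O=C(Nc1cccc(C(F)(F)F)c1)N[C@H]1CC[C@H](Oc2ccccc2F)CC1` gives 2450 nM, the only number among the three.

Within the data shown here, compound 2 therefore stands as the single measured value, with the other two at a limit. Among the measured compounds shown here, the one step between measured compounds, a step that the two limits leave unreadable from compound 1 to compound 3, is unreadable since both ends sit at the limit (the limit of > 20000 nM in this assay, at which 2 of the 3 values shown sit), and it does not touch the side changed here. Compound 4 `O=C(Nc1cccc(C(F)(F)F)c1)N[C@H]1CC[C@H](Oc2cccc(C(F)(F)F)c2)CC1` differs from compound 2 by 3-(trifluoromethyl)phenyl in place of 2-fluorophenyl on an oxygen on a saturated carbon. For the measured compounds named here, no measured step bears on this change, so no direction beyond the scatter is expected. Compound 4 is estimated at 2500 nM, between 800 nM and 8000 nM, meaning an expected step of a 1.0-fold higher number from compound 2 to compound 4 (0.01 log units; within the scatter).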

Compound 4, half-maximal inhibitory concentration: 1300 nM
Beside the measured number, compound 4's estimate is 1.9-fold (0.28 log units) above it; low and high end bracket the measured number.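

In this assay, within the data shown here, the first readable step at this position is a 1.9-fold lower number from compound 2 to compound 4 (0.28 log units; within the scatter) when 3-(trifluoromethyl)phenyl replaces 2-fluorophenyl on the oxygen. The earlier compounds shown here gave no such step, and this one shows that the two groups can be exchanged here with no shift beyond the scatter. No measured property available here bears on this step. From the compounds shown here alone, what an amine or a carboxylic acid on this ring would do stays open. So does whether the same exchange would read alike with a different group on the other side of the molecule.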